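The source may report more compounds than this note shows. Statements on the series, on what has been measured and on what is new or still open speak of the compounds shown alone.

Compound 1 `O=C(Nc1ccc(Oc2cc(O)ncn2)cc1)Nc1cccc(C(F)(F)F)c1`: 3200 nM
Compound 2 `COc1cc(Oc2ccc(NC(=O)Nc3cccc(C(F)(F)F)c3)cc2)ncn1`: 4000 nM
Compound 3 `CN(C)c1cc(Oc2ccc(NC(=O)Nc3cccc(C(F)(F)F)c3)cc2)ncn1`: 2500 nM

In an assay on isolated protein for inhibition of serine/threonine-protein kinase TNNI3K (Homo sapiens) (a higher number here means a weaker inhibitor, a lower number a stronger inhibitor), compound 3 gives 2500 nM, the lowest of the three numbers, yet the steps leading to it, a 1.3-fold lower number from compound 1 to compound 3 (0.11 log units; within the scatter) and a 1.6-fold lower number from compound 2 to compound 3 (0.20 log units; within the scatter), both stay within the scatter. Compound 4 `CC(C)(O)CNc1cc(Oc2ccc(NC(=O)Nc3cccc(C(F)(F)F)c3)cc2)ncn1` carries (2-hydroxy-2-methylpropyl)amino in place of dimethylamino on an aromatic carbon. The three measured steps all change the same position of the shared core, a 1.3-fold higher number from compound 1 to compound 2 (0.10 log units; within the scatter) included, and none of them moved the number beyond the scatter. Among the measured compounds shown here, the change to compound 4 is larger in what enters, but the series so far gives no sign of a large effect at this position, so compound 4 is expected to show no step beyond the scatter, no change at the digits printed from compound 3 to compound 4 (within the scatter). Compound 4 is therefore estimated at 2500 nM, with a range from 1000 nM to 6300 nM.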

Compound 4, half-maximal inhibitory concentration: 40 nM
Estimate against measurement, compound 4: 63-fold (1.80 log units) above; the measured number lies below the stated range.
By their numbers in this assay, from the lowest: compound 4; then compounds 3, 1 and 2 (each within the scatter of the next).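

In (this assay) this position, which had stayed within the scatter across hydroxy, methoxy and dimethylamino, proves highly sensitive to the group it carries: (2-hydroxy-2-methylpropyl)amino gives a 63-fold lower number from compound 3 to compound 4 (1.80 log units; beyond the scatter) and a 100-fold lower number from compound 2 to compound 4 (2.00 log units; beyond the scatter) and also an 80-fold lower number from compound 1 to compound 4 (1.90 log units; beyond the scatter) (all large). The three earlier groups therefore gave no sign of how far the number can move at this place. Nothing measured here explains the size of these steps.

The compounds shown leave open which part of the entering group matters: the hydrogen on the amine nitrogen, the hydroxy or the branching methyl groups. A methylamino, an isobutylamino or a 2-hydroxyethylamino group would separate these.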